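Amide substituent change in an anti-inflammatory paw edema series

This account rests on a few compounds, and the source may have more. Where it says the series, first, only, none or still open, it means among the compounds named here.

Measured compounds:
compound 1 `CNC(=O)CC1CCc2cc(OC)c(OC)cc21`, 24.1%
compound 2 `COc1cc2c(cc1OC)C(CC(=O)NC1CCCC1)CC2`, 40.7%

For the measured compounds named here, in a functional assay on the whole organism (strain Wistar) for inhibition, with Rattus norvegicus as the target, read by paw edema, with stated times of 60 min and 6 h, at a dose of 100 mg/kg by the oral route (a lower number here means less inhibition, a higher number more inhibition at the dose given (going by the name of the read-out)), compound 2 gives 40.7%, the highest of the two numbers measured so far, and compound 1 gives 24.1%. Going by the values given here, the one measured step, a number 16.6 percentage points higher from compound 1 to compound 2 (beyond the scatter), shows what a change of the group on the amide-type nitrogen can do within this pair.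

Compound 3 `COc1cc2c(cc1OC)C(CC(=O)NCCO)CC2` has not yet been measured. It differs from compound 2 in one place: 2-hydroxyethyl in place of cyclopentyl on an amide-type nitrogen. The step from compound 1 to compound 2 bears on this change, since both concern the group on the amide-type nitrogen; that step was a number 16.6 percentage points higher from compound 1 to compound 2 (beyond the scatter). Among the compounds with values here, compound 3 carries a smaller group than compound 2, as compound 1 does, so a drop in this assay is expected, though the hydrogen-bond donor and acceptor that enter have no measured precedent here. The expected step is a number 12.7 percentage points lower from compound 2 to compound 3 (beyond the scatter). Compound 3 is therefore estimated at 28%, with a likely range from 14% to 42%.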

Compound 3, a percentage reported as inhibition, in the whole organism at one dose (the size of the read-out at that dose, not a potency): 13%
Estimate against measurement, compound 3: 15 percentage points above; measured number outside the range, below it.
By their numbers in this assay, from the lowest: compound 3; then compound 1; then compound 2.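

Within this assay, the group on the amide-type nitrogen can now move the number down as well as up: replacing cyclopentyl with 2-hydroxyethyl gives a number 27.7 percentage points lower from compound 2 to compound 3 (beyond the scatter), which places compound 3 under both earlier compounds. The second comparison adds to this, since hydroxymethyl in place of hydrogen on the saturated chain carbon bound to the amide-type nitrogen gives a number 11.1 percentage points lower from compound 1 to compound 3 (beyond the scatter), so a group that adds atoms to the methyl of compound 1 does not raise the number as cyclopentyl did, and the earlier step, a number 16.6 percentage points higher from compound 1 to compound 2 (beyond the scatter), cannot be read as a simple gain with every added atom, with compound 3 going against that reading. Nothing measured on these compounds accounts for the fall, and the reason for it remains unexplained.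

The compounds shown leave open whether the drop goes with the hydroxyl or with the open chain, a question that an ethyl or a 2-methoxyethyl group on the same nitrogen would help to settle. They also leave open how a cyclohexyl ring, or a 2-aminoethyl chain, would read in this assay.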